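The source may hold more compounds than are shown below. What is called first, only, known or untested is meant among the compounds shown, and "the series" means these compounds.

Compound 3, `C[C@H](Nc1nc(N)nc(N)c1C#N)c1cc(=O)n2cc(F)ccc2c1-c1ccccc1`, is one of three measured members of a small series built on a shared core. In an ADME assay on microsomes from liver (Rattus norvegicus), read by LC-MS, using NADPH, with a stated time of 30 min, tested at 1 uM (a higher number here means that more of the compound is left, a lower number that less of the compound is left), compound 3 gives "not determined" (no result reported), so no single number places it on the scale; the same holds for compound 1, `Cc1ccc2cc([C@H](C)Nc3ncnc(N)c3C#N)c(-c3ccccc3)c(=O)n2c1`, which in this assay gives "not determined" (no result reported). Among the measured compounds shown here, the only number in the set belongs to compound 2, `Cc1nc(N)nc(N[C@@H](C)c2cc3ccc(F)cn3c(=O)c2-c2ccccc2)c1C#N`, which in this assay gives 41%.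

Compound 4, `C[C@H](Nc1ncnc(N)c1C#N)c1cc(=O)n2cc(F)ccc2c1-c1ccccc1`, is the next compound to be tested. Its change from compound 3 is hydrogen in place of amino on an aromatic carbon, a step that reads as 2,6-diamino-5-cyanopyrimidin-4-yl to 6-amino-5-cyanopyrimidin-4-yl. For the measured compounds named here, no measured pair in this set shares that change, so no step can be read from the data, and with compound 3 itself without a number, nothing fixes a direction for this assay. Going by the values given here, the one anchor is compound 2, whose core bears a methyl where compound 4 bears hydrogen. In this assay compound 2 gives 41%.

On that basis compound 4 is expected to give about 40% in this assay, with a likely range from 15% to 70%.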

Compound 4, percent of the compound remaining: 74%
Beside the measured number, compound 4's estimate is 34 percentage points below it; the whole stated range lies below it.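

With compound 3 giving no single number in this assay, no step can be read from compound 3 to compound 4, and no other pair shown yields one. Nothing shown here offers an explanation for the result of compound 4. The compounds shown leave open how going from 2,6-diamino-5-cyanopyrimidin-4-yl to 6-amino-5-cyanopyrimidin-4-yl shifts the result in this assay on the shared core.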